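Hydroxy to Chloro on a Shared Core

The compounds below may be only part of what the source reports. "The series", "measured", "known", "first", "only" and "open" are said of these compounds alone.

Of the compounds shown here, two of this shared core have been measured. Compound 2 `COc1ccc(/C=N/N(C)C(=O)c2ccc(O)cc2)cc1OC` gives 61% in a functional assay on the whole organism (strain A/J) for inhibition, with Mus musculus as the target, with stated times of 1 h and 18 h, at a dose of 100 umol/kg by the oral route (on this read-out lower numbers stand for less inhibition and higher numbers for more inhibition at the one dose given (going by the name of the read-out)), and its nearest neighbour, compound 1 `COc1ccc(/C=N/N(C)C(=O)c2ccccc2OC)cc1OC`, gives 59% in this assay; the step of a number 2 percentage points higher from compound 1 to compound 2 (within the scatter) sits within the scatter, so the two stand together. The unmeasured compound 3 `COc1ccc(/C=N/N(C)C(=O)c2ccc(Cl)cc2)cc1OC` differs from compound 2 in one place: chloro in place of hydroxy on an aromatic carbon. Among the measured compounds shown here, the only measured step, from compound 1 to compound 2, concerns a different change, 4-hydroxyphenyl in place of 2-methoxyphenyl on a carbonyl carbon, and it was small. For the measured compounds named here, no measured step bears directly on exchanging hydroxy for chloro at this position. Because of the small step of a number 2 percentage points higher from compound 1 to compound 2 (within the scatter), the expected change a number 1 percentage points lower from compound 2 to compound 3 (within the scatter) is none beyond the scatter. Compound 3 is therefore estimated at 60%, with a range from 44% to 76%.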

Compound 3, a percentage reported as inhibition, in the whole organism at one dose (the size of the read-out at that dose, not a potency): 72%
Estimate against measurement, compound 3: 12 percentage points below; the measured number falls inside the stated range.
By their numbers in this assay, from the lowest: compounds 1 and 2 (each within the scatter of the next); then compound 3.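

Among the compounds shown here, at this place, para to a large group on the six-membered aromatic ring, the exchange of hydroxy for chloro gives the first step beyond the scatter in this assay: a number 11 percentage points higher from compound 2 to compound 3 (beyond the scatter). The group on the carbonyl carbon therefore matters in this series, and 4-chlorophenyl in place of 2-methoxyphenyl also clears the scatter, with a number 13 percentage points higher from compound 1 to compound 3 (beyond the scatter), while 4-hydroxyphenyl in its place does not. No measurement given here accounts for this gain with chloro.

The compounds shown leave open whether the gain belongs to chloro itself or follows from the loss of hydroxy. A methyl, a fluoro or an amine at the same place would help to tell these two readings apart.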